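The compounds below may be only part of what the source reports. "The series", "measured", "known", "first", "only" and "open" are said of these compounds alone.

Working notes on the series. Compound 1 `O=C(Nc1ccc(C(F)(F)F)cc1)c1cc(=O)[nH]c2cc(Br)ccc12` carries trifluoromethyl, compound 2 `CC(C)(C)c1ccc(NC(=O)c2cc(=O)[nH]c3cc(Br)ccc23)cc1` tert-butyl on the same core. In a functional assay on KYSE-70 cells for antiproliferative activity against KYSE-70 cell line (Homo sapiens), read by MTT assay, with a stated time of 72 h (on this read-out higher numbers stand for weaker inhibition and lower numbers for stronger inhibition), compound 1 gives only the assay limit > 20000 nM. Compound 2 likewise gives only the limit > 20000 nM in this assay. The step that the two limits leave unreadable from compound 1 to compound 2 cannot be sized. Compound 3 `CC(C)(C)c1ccc(-c2ccc3c(C(=O)Nc4cccc(F)c4)cc(=O)[nH]c3c2)cc1` bears 4-(tert-butyl)phenyl; in this assay compound 3 gives only the limit > 20000 nM, standing where every value shown stands (the limit of > 20000 nM in this assay, at which 3 of the 3 values shown sit). Compound 4 `O=C(Nc1cccc(F)c1)c1cc(=O)[nH]c2cc(-c3ccc(F)nc3)ccc12` differs by 6-fluoropyridin-3-yl in place of 4-(tert-butyl)phenyl on an aromatic carbon. No readable measured step bears on this change. The step that the limit leaves unreadable from compound 3 to compound 4 is expected to be none beyond the scatter. Compound 4 is expected at 25000 nM, within 8000 nM to 60000 nM, most likely again reported as a limit.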

Compound 4, half-maximal inhibitory concentration: > 20000 nM
Compound 4: no number, only a limit (the forecaster's own chance of this, stated with the estimate: 75%); the middle value is on the limit's open side.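

Among the compounds shown here, compound 3 and compound 4 each give only a limit in this assay, so no step between them can be read. The compounds shown leave open how any of these changes affects activity: the limit of > 20000 nM in this assay, at which 4 of the 4 values shown sit.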